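Chloro for Hydrogen on the Chromone Core of Compound 3

The source may report more compounds than this note shows. Statements on the series, on what has been measured and on what is new or still open speak of the compounds shown alone.

Of the compounds shown here, three have been measured in a functional assay on LM7 cells (Homo sapiens) for antiproliferative activity, read by MTT assay, with a stated time of 72 h; a lower number here means a stronger inhibitor, a higher number a weaker inhibitor. Compound 1 `O=c1c(CSC(=S)N2CCOCC2)coc2cc(Cl)ccc12` gives 6200 nM, and compound 2 `Cc1ccc2c(=O)c(CSC(=S)N(C(C)C)C(C)C)coc2c1` gives 6300 nM. Among the compounds with values here, compound 3 `CC(C)N(C(=S)SCc1coc2ccccc2c1=O)C(C)C` gives 21900 nM in this assay, the highest of the three numbers, and the single one-point step recorded, a 3.5-fold higher number from compound 2 to compound 3 (0.54 log units; beyond the scatter), shows that removing the methyl group weakened the inhibitor by a modest but real margin.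

Compound 4 `CC(C)N(C(=S)SCc1coc2cc(Cl)ccc2c1=O)C(C)C` differs from compound 3 by chloro in place of hydrogen on an aromatic carbon. Within the data shown here, no measured step matches this exact change. Among the measured compounds shown here, the only comparison that bears on it is indirect: compound 1, which carries a chloro group on the same core but a different amine, gives 6200 nM, while the hydrogen-bearing compound 3 sits well above it. Compound 4 is therefore expected to show a lower number than compound 3, with a step of about a 3.4-fold lower number from compound 3 to compound 4 (0.53 log units; beyond the scatter) in this assay. Compound 4 is estimated at 6500 nM, within a range from 2500 nM to 17000 nM.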

Compound 4, half-maximal inhibitory concentration: > 25000 nM
Compound 4: no number, only a limit; the forecaster's own chance of this, stated with the estimate: 5%; middle value at least 3.8-fold (0.58 log units) away from the limit.
By their numbers in this assay, from the lowest: compounds 1 and 2 (each within the scatter of the next); then compound 3. At a limit, above all of these: compound 4.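

Compound 4 gives no number in this assay, only a limit: the limit of > 25000 nM in this assay, at which 1 of the 4 values shown sits. On the core bearing diisopropylamino, chloro in place of hydrogen on this aromatic carbon brings no lower number, yet an at least 1.1-fold higher number from compound 3 to compound 4 (0.05 log units; that floor lies within the scatter) leaves open whether the change raises the number at all. The other two steps are clearer: chloro in place of methyl at this position gives an at least 3.9-fold higher number from compound 2 to compound 4 (0.59 log units; beyond the scatter), so with diisopropylamino the two groups are not interchangeable here, and with chloro held in place, diisopropylamino in place of morpholin-4-yl gives an at least 4.0-fold higher number from compound 1 to compound 4 (0.60 log units; beyond the scatter), so chloro alone does not set the number.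

From the compounds shown here alone, how far compound 4 lies past its limit remains unknown. Also open, going by these compounds, is how a fluoro or a methoxy group on this aromatic carbon would compare with methyl and chloro.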